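Straightening a Branched Chain on a Second Core

The source may hold more compounds than are shown below. What is called first, only, known or untested is meant among the compounds shown, and "the series" means these compounds.

Compound 1 `CC(C)/C=C/C(=O)Nc1cc2c(N3CCc4ccccc43)ncnc2cc1O[C@@H]1CCOC1`, compound 2 `CCC/C=C/C(=O)Nc1cc2c(N3CCc4ccccc43)ncnc2cc1O[C@@H]1CCOC1` and compound 3 `CC(C)/C=C/C(=O)Nc1cc2c(N3CCCc4ccccc43)ncnc2cc1O[C@@H]1CCOC1` have all been tested in a functional assay on MCF7 cells (Homo sapiens) for antiproliferative activity, read by MTT assay, with a stated time of 72 h; on this read-out lower numbers stand for stronger inhibition and higher numbers for weaker inhibition. Compound 1 gives 9880 nM, compound 2 gives 4550 nM and compound 3 gives 4680 nM. The change from compound 1 to compound 2 is propyl in place of isopropyl on a double-bonded chain carbon bound to a double-bonded chain carbon, and it made a 2.2-fold lower number from compound 1 to compound 2 (0.34 log units; beyond the scatter). The cores of compound 1 and compound 3 differ by 1,2,3,4-tetrahydroquinolin-1-yl in place of 2,3-dihydro-1H-indol-1-yl on an aromatic carbon, a step of a 2.1-fold lower number from compound 1 to compound 3 (0.32 log units; beyond the scatter). Going by the values given here, compound 4 `CCC/C=C/C(=O)Nc1cc2c(N3CCCc4ccccc43)ncnc2cc1O[C@@H]1CCOC1` has not yet been measured; it differs from compound 3 by propyl in place of isopropyl on a double-bonded chain carbon bound to a double-bonded chain carbon, which is the same change at the same place as the one from compound 1 to compound 2. Resting on that single earlier step, compound 4 is expected to show a 2.2-fold lower number from compound 3 to compound 4 (0.35 log units; beyond the scatter) in this assay. The estimate for compound 4 is 2100 nM, with a range from 1000 nM to 4500 nM, because it rests on a 2.2-fold lower number from compound 1 to compound 2 (0.34 log units; beyond the scatter) alone.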

Compound 4, half-maximal inhibitory concentration: 4230 nM
Compound 4: the middle estimate sits 2.0-fold (0.30 log units) below what was measured; the measured number falls inside the stated range.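

With propyl in place of isopropyl, the core of compound 3 gave a 1.1-fold lower number from compound 3 to compound 4 (0.04 log units; within the scatter) in this assay, and exchanging the core with propyl already in place gave a 1.1-fold lower number from compound 2 to compound 4 (0.03 log units; within the scatter). Neither step stands out from the usual scatter, yet this does not show that the change fails to carry over, since the new step cannot be told apart from the earlier one either: the same change on two cores in this assay, a 2.2-fold lower number (0.34 log units; beyond the scatter) from compound 1 to compound 2 and a 1.1-fold lower number (0.04 log units; within the scatter) from compound 3 to compound 4, 2.0-fold (0.29 log units) apart, within the scatter of two such steps. The core exchange reads the same way, so these four compounds neither confirm nor rule out that either change carries across: the same change on two cores in this assay, a 2.1-fold lower number (0.32 log units; beyond the scatter) from compound 1 to compound 3 and a 1.1-fold lower number (0.03 log units; within the scatter) from compound 2 to compound 4, 2.0-fold (0.29 log units) apart, within the scatter of two such steps.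

On these data alone, what a longer chain or an amine in place of propyl would do on either core stays open.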